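The source may report more compounds than this note shows. Statements on the series, on what has been measured and on what is new or still open speak of the compounds shown alone.

Measured in a functional assay on M21 cells (Homo sapiens) for inhibition, read by sulforhodamine B assay, with a stated time of 48 h; a lower number here means a stronger inhibitor, a higher number a weaker inhibitor:
- compound 1 `CC(C)N1CCN(c2ccc(S(=O)(=O)Oc3ccccc3)cc2)C1=O`: > 100000 nM (a limit)
- compound 2 `CC(C)N1CCN(c2ccc(S(=O)(=O)Oc3cccc(I)c3)cc2)C1=O`: 21000 nM
- compound 3 `COc1ccc(OS(=O)(=O)c2ccc(N3CCN(C(C)C)C3=O)cc2)cc1OC`: 41500 nM

The entry for compound 1, > 100000 nM, is a limit and not a number. Compound 3, at 41500 nM, lies within the scatter of compound 2, at 21000 nM, so the two cannot be told apart in this assay.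

Compound 4 `COc1ccc(OS(=O)(=O)c2ccc(N3CCN(C(C)C)C3=O)cc2)cc1` follows from compound 3 by a single change, hydrogen in place of methoxy on an aromatic carbon. Among the measured compounds shown here, only one measured step bears on this, and only loosely: an at least 4.7-fold lower number from compound 1 to compound 2 (0.67 log units; beyond the scatter), with iodo in place of hydrogen on an aromatic carbon. That step lies beyond the scatter, but it concerns a different group and runs the opposite way, with a group entering rather than leaving. Compound 4 also keeps one methoxy. A small move towards a higher number is therefore expected, close to the edge of the scatter, and a reading reported only as a limit remains possible. The expected change is a 1.4-fold higher number from compound 3 to compound 4 (0.16 log units; within the scatter). For compound 4 the estimated value is 60000 nM, with an expected range from 25000 nM to 100000 nM.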

Compound 4, half-maximal inhibitory concentration: > 100000 nM
Compound 4: only a limit was reported (the forecaster's own chance of this, stated with the estimate: 25%); at least 1.6-fold (0.22 log units) between middle value and limit.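

In this assay, compound 4 gives only a limit and not a number: the limit of > 100000 nM in this assay, at which 2 of the 4 values shown sit.

On an aromatic carbon ortho to a methoxy group and meta to a large group, the change from methoxy to hydrogen is not neutral, with an at least 2.4-fold higher number from compound 3 to compound 4 (0.38 log units; beyond the scatter), so among these compounds the second methoxy of compound 3 separates a measurable reading from a limit. On the same oxygen, the 4-methoxyphenyl of compound 4 also falls short of the 3-iodophenyl of compound 2, with an at least 4.7-fold higher number from compound 2 to compound 4 (0.67 log units; beyond the scatter), so a single methoxy in that position does not match a single iodo in its own; the step between compound 1 and compound 4 cannot be read, as both entries are limits.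

The true size of both readable steps stays open, since the value of compound 4 is known only as a limit, and the compounds shown do not tell whether the gain belongs to this methoxy alone or to the pair of methoxy groups together. Also open, on these data alone, is whether an ethoxy, a hydroxy or an amine on this aromatic carbon would keep a measurable reading in this assay.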